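A few compounds are considered here, and "the series" means these few. Any claim that something is new, unique, unknown or untested is made for them only; others in the source may bear on it.

Permeability notes on the series.

For the measured compounds named here, compound 2 `CCN1CC(CC#N)(n2cc(-c3nc(-c4cnn(C)c4)cn4nccc34)cn2)C1` stands highest of the three numbers so far in an ADME assay on MDCK-II cells (Canis lupus familiaris) for permeability (on this read-out higher numbers stand for higher permeability and lower numbers for lower permeability), giving 33 10^-6 cm/s. Compound 1 `N#CC[C@]1(n2cc(-c3nc(-c4cn[nH]c4)cn4nccc34)cn2)C[C@H](C#N)C1` gives 7 10^-6 cm/s in this assay, and compound 3 `N#CC[C@]1(n2cc(-c3nc(-c4cn[nH]c4)cn4nccc34)cn2)C[C@@H](C#N)C1` gives 6 10^-6 cm/s. Compounds 1 and 3 are mirror images, and the step of a 1.2-fold lower number from compound 1 to compound 3 (0.07 log units; within the scatter) is as small as would be expected given (the fact that compounds 1 and 3 differ only in the configuration as drawn). Going by the values given here, no single-change step links compound 2 to either of them, so their values can only be set side by side.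

Compound 4 `CC(=O)N1CC(CC#N)(n2cc(-c3nc(-c4cnn(C)c4)cn4nccc34)cn2)C1` differs from compound 2 in one place: acetyl in place of ethyl on an amine nitrogen in a ring. Among the compounds with values here, none of the measured steps covers a change of this kind; the only measured step is the stereochemical one within the scatter, which says nothing about a substituent on an amine nitrogen in a ring. The expectation for this assay is therefore weakly held: a step of at most modest size, more likely downward than upward, but possibly none beyond the scatter. The step of a 1.7-fold lower number from compound 2 to compound 4 (0.22 log units; within the scatter) is what this estimate means. Compound 4 is expected to give about 20 10^-6 cm/s in this assay, within a range from 8 10^-6 cm/s to 45 10^-6 cm/s.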

Compound 4, apparent permeability in the MDCK-II assay: 4 10^-6 cm/s
The estimate for compound 4 lay 5.0-fold (0.70 log units) above the measured number; the measured number lies below the stated range.
By their numbers in the MDCK-II assay, from the lowest: compounds 4, 3 and 1 (each within the scatter of the next); then compound 2.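

For the compounds shown here, the amine nitrogen of the four-membered ring is the first place where a single change moves the number: in the MDCK-II assay acetyl in place of ethyl, which brings in a hydrogen-bond acceptor and a double bond outside aromatic rings, gives an 8.3-fold lower number from compound 2 to compound 4 (0.92 log units; beyond the scatter), whereas the only earlier step was a stereochemical one within the scatter. In a physicochemical assay for lipophilicity, using the shake flask method, in phosphate buffer, measured as octanol-water partition, at pH 7.4 (on this read-out higher numbers stand for higher lipophilicity and lower numbers for lower lipophilicity), compound 2 gives 2.1 and compound 4 gives 1.2, and the same change reads as a number 0.90 log units lower from compound 2 to compound 4 (beyond the scatter) in this pair. The lower permeability of compound 4 may therefore go with its lower lipophilicity, though a single pair cannot separate this from any other difference between ethyl and acetyl: (the measured distribution coefficient of compound 2, 2.1, and of compound 4, 1.2, a number 0.90 log units lower (beyond the scatter)).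

Going by these compounds, whether permeability follows the distribution coefficient at this nitrogen beyond this one pair stays open, and a longer chain such as propyl or a sulfonyl group such as methanesulfonyl on the same nitrogen would test it. On these data alone, compound 1 and compound 3 differ from compound 4 in more than one place, so how the acetyl step would read on another core also stays open.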